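Swapping Phenyl for Methyl on a Bromine-Bearing Chain Carbon

This account rests on a few compounds, and the source may have more. Where it says the series, first, only, none or still open, it means among the compounds named here.

Compound 1 `C=C1CC(CI)(c2ccccc2)OC1=O` gives 2720 nM
Compound 2 `C=C1CC(c2ccccc2)(C(Br)c2ccccc2)OC1=O` gives 4190 nM

In a functional assay on A-431 cells (Homo sapiens) for antiproliferative activity, read by sulforhodamine B assay, with a stated time of 72 h (on this read-out higher numbers stand for weaker inhibition and lower numbers for stronger inhibition), compound 1 gives 2720 nM and compound 2 gives 4190 nM. These two values lie within the scatter of each other, so compound 2 cannot be ranked against compound 1. Compound 3 `C=C1CC(c2ccccc2)(C(C)Br)OC1=O` has not yet been measured. It departs from compound 2 by methyl in place of phenyl on a saturated chain carbon bound to a bromine atom and a saturated ring carbon. Among the compounds with values here, no measured pair shows what such a change does. Within the data shown here, the only guide is how close compound 1 at 2720 nM and compound 2 at 4190 nM lie, so no step beyond the scatter is expected in this assay, in either direction. The expected change is a 1.0-fold lower number from compound 2 to compound 3 (0.02 log units; within the scatter). Compound 3 is estimated at 4000 nM, with an expected range from 1800 nM to 9000 nM.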

Compound 3, half-maximal inhibitory concentration: 5240 nM
The estimate for compound 3 lay 1.3-fold (0.12 log units) below the measured number; the range from low to high includes it.
By their numbers in this assay, from the lowest: compounds 1, 2 and 3 (each within the scatter of the next).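

In this assay, within the data shown here, methyl in place of phenyl on a saturated chain carbon bound to a bromine atom and a saturated ring carbon gives a 1.3-fold higher number from compound 2 to compound 3 (0.10 log units; within the scatter), so at this position the six-membered aromatic ring can be exchanged for a single carbon with no step that can be read beyond the scatter. The second step, 1-bromoethyl in place of iodomethyl on a saturated ring carbon, gives a 1.9-fold higher number from compound 1 to compound 3 (0.28 log units; within the scatter) and likewise stays within the scatter. Nothing measured here speaks to why these steps are so small.

As far as these compounds go, whether an amine, a carboxylic acid or a longer chain on this chain carbon would move the number beyond the scatter remains open. So does the part played by the bromine atom itself, which a hydroxyl group at the same carbon could test.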